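Working notes on two weak antagonists and a third

The source may report more compounds than this note shows. Statements on the series, on what has been measured and on what is new or still open speak of the compounds shown alone.

Compound 1 `O=C(Nc1ccccn1)c1ccccc1-c1ccccc1` and compound 2 `COc1ccc(OCCCCCN2CCCC(COC(=O)c3ccccc3-c3ccccc3)C2)cc1` have been tested in an in vitro functional assay on HEK ts201 cells for antagonist activity at Neuronal acetylcholine receptor; alpha3/beta4 (Homo sapiens), read by fluorescence and calcium flux; a lower number here means a stronger inhibitor, a higher number a weaker inhibitor. In this assay compound 1 gives 17500 nM. Compound 2 gives 22400 nM, which sits at the top of the two numbers shown, though its gap to compound 1 lies within the scatter, so the two read as alike and neither can be called the weaker. Compound 3 `O=C(OCC1CCCN(CCCn2cc(-c3ccccc3)nn2)C1)c1ccccc1-c1ccccc1` has not been measured. It differs from compound 2 in one place: 4-phenyl-1H-1,2,3-triazol-1-yl in place of 2-(4-methoxyphenoxy)ethyl on a saturated chain carbon, three bonds along the chain from an amine nitrogen in a ring. Going by the values given here, no step between measured compounds speaks to this change, so nothing points to a direction. The working expectation is a step of modest size at most, in either direction, with the likeliest outcome inside the scatter, and a 1.1-fold lower number from compound 2 to compound 3 (0.05 log units; within the scatter) is what is expected. Compound 3 is accordingly estimated at 20000 nM, with a range from 7000 nM to 60000 nM.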

Compound 3, half-maximal inhibitory concentration: 389000 nM
For compound 3 the middle estimate is 19-fold (1.29 log units) below the measured one; the whole stated range lies below it.
By their numbers in this assay, from the lowest: compounds 1 and 2 (each within the scatter of the next); then compound 3.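

Going by these compounds alone, this place on the chain is not indifferent in this assay: 4-phenyl-1H-1,2,3-triazol-1-yl in place of 2-(4-methoxyphenoxy)ethyl gives a 17-fold higher number from compound 2 to compound 3 (1.24 log units; beyond the scatter) and so shows a large loss of inhibition, where the earlier compounds offered no step at all. The two groups have the same heavy-atom count, and each carries one six-membered aromatic ring of carbon only and no hydrogen-bond donors, so these shared counts do not separate them; they differ in the five-membered aromatic ring with 3 hetero atoms that enters and the oxygen atoms that leave. Nothing at hand explains the loss.

Open, from the compounds shown here alone, is which part of the change carries the step. A plain phenoxy group or an unsubstituted 1,2,3-triazole at this place could help to separate the contributions of the ring and its substituent.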